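This account rests on a few compounds, and the source may have more. Where it says the series, first, only, none or still open, it means among the compounds named here.

Compound 1 `Cc1cc(O)cc(-c2nn(CC#N)cc2-c2ccnc(-c3ccc(Oc4ccccc4)cc3)c2)c1` and compound 2 `COc1cc(C)cc(-c2nn(CC#N)cc2-c2ccnc(-c3ccc(N(C)C)cc3)c2)c1` share one core and differ at two places. In a functional assay on SK-MEL-5 cells (Homo sapiens) for inhibition, read by sulforhodamine B assay, with a stated time of 48 h (on this read-out lower numbers stand for higher toxicity in this test and higher numbers for lower toxicity in this test), compound 1 gives 31500 nM. In this assay compound 2 gives 24000 nM, the lower of the two numbers, though its gap to compound 1 lies within the scatter. Compound 3 `Cc1cc(O)cc(-c2nn(CC#N)cc2-c2ccnc(-c3ccc(N(C)C)cc3)c2)c1` is not yet measured; it differs from compound 2 by hydrogen in place of methyl on an oxygen on an aromatic ring. For the measured compounds named here, no measured pair shows this change on its own, so no step beyond the scatter is expected. For compound 3 the estimate is 26000 nM, with a range from 10000 nM to 65000 nM, meaning an expected step of a 1.1-fold higher number from compound 2 to compound 3 (0.03 log units; within the scatter).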

Compound 3, concentration lethal to 50% of the cells: 22900 nM
Compound 3: the middle estimate sits 1.1-fold (0.06 log units) above what was measured; the range from low to high includes it.
By their numbers in this assay, from the lowest: compounds 3, 2 and 1 (each within the scatter of the next).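

In this assay hydrogen in place of methyl on an oxygen on an aromatic ring gives a 1.0-fold lower number from compound 2 to compound 3 (0.02 log units; within the scatter) and so shows, for this change read on its own, no step beyond the scatter. Dimethylamino in place of phenoxy on an aromatic carbon gives a 1.4-fold lower number from compound 1 to compound 3 (0.14 log units; within the scatter) and also stays within the scatter. Neither the methoxy nor the hydroxy form of the 3-substituted 5-methylphenyl group separates from the other here. On these data alone, whether an ethyl chain on this oxygen or an amine in place of the hydroxy would move the number stays open. No evidence at hand bears on these results.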